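Fluoro for bromo on the fused ring of compound 3

This account rests on a few compounds, and the source may have more. Where it says the series, first, only, none or still open, it means among the compounds named here.

Three compounds carry the tetrazole on related cores. Compound 1 `COc1ccc2c(=O)c(-c3nn[nH]n3)c[nH]c2c1`, bearing a methoxy group, gives 10 mg/kg in a functional assay on the whole organism (strain Sprague-Dawley) for inhibition, with Rattus norvegicus as the target; a lower number here means that less compound is needed, a higher number that more compound is needed for the effect. Compound 2 `COc1cccc2cc(-c3nn[nH]n3)cnc12`, on a different core, gives 2.5 mg/kg in this assay. For compound 3 `O=c1c(-c2nn[nH]n2)c[nH]c2c(Br)cccc12` only a limit is known: in this assay compound 3 gives > 5 mg/kg, which is a limit of the assay and not a number (the limit of > 5 mg/kg in this assay, at which 1 of the 3 values shown sits). Compound 3 therefore cannot be placed against compound 1 or compound 2 on the numbers shown.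

Compound 4 `O=c1c(-c2nn[nH]n2)c[nH]c2c(F)cccc12` differs from compound 3 in one place: fluoro in place of bromo on an aromatic carbon. The halogen sits on an aromatic carbon of the six-membered carbon ring of the fused system, ortho to a fused ring and meta to a fused ring.

Going by the values given here, no measured step connects a bromo and a fluoro compound here, so the size of the step from compound 3 to compound 4 in this assay is expected to be small, with no clear direction beyond the scatter; the step that the limit leaves unreadable from compound 3 to compound 4 is the estimate. For compound 4 the minimum effective dose in this assay is estimated at 10 mg/kg, within 4 mg/kg to 30 mg/kg, with a real chance that again only a limit is returned.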

Compound 4, minimum effective dose: 0.625 mg/kg
The estimate for compound 4 lay 16-fold (1.20 log units) above the measured number, and the stated range ends above it.
By their numbers in this assay, from the lowest: compound 4; then compound 2; then compound 1.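

On an aromatic carbon of a six-membered aromatic ring of carbon only, ortho to a fused ring and meta to a fused ring, the choice of halogen changes the result in this assay: fluoro in place of bromo gives an at least 8.0-fold lower number from compound 3 to compound 4 (0.90 log units; beyond the scatter). Going by these compounds alone, the earlier compounds offered no pair differing in one place, so this is the first readable step. The step is a bound and not a full size, because compound 3 stands at a limit of the assay and not at a number: the limit of > 5 mg/kg in this assay, at which 1 of the 4 values shown sits.

Open, from the compounds shown here alone, is whether chloro, hydrogen or an amine at this place would read closer to compound 3 or to compound 4. Also open, going by these compounds, is whether the same exchange of bromo for fluoro gives a step of similar size on another core.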